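The compounds below may be only part of what the source reports. "The series", "measured", "known", "first", "only" and "open" are said of these compounds alone.

Within the data shown here, only one number is available so far for this small family of compounds, which share a common core. In a functional assay on MOLT-4 cells (Homo sapiens) for inhibition, read by MTT assay, with a stated time of 48 h (a higher number here means a weaker inhibitor, a lower number a stronger inhibitor), compound 1 `C=C(C)Cn1cc(/C=C/C(=O)CC(=O)C(=O)OCC)c2ccccc21` has the entry "not determined" (no result reported) and offers nothing to compare. Compound 2 `CCOC(=O)C(=O)CC(=O)/C=C/c1cn(Cc2ccc(F)cc2)c2ccccc12` likewise has the entry "not determined" (no result reported) in this assay and adds no figure either. Among the measured compounds shown here, compound 3 `C=C(C)Cn1cc(/C=C/C(=O)CC(=O)C(=O)O)c2ccccc21` gives 40000 nM in this assay as the only measured value, so it cannot yet be ranked against anything.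

The next candidate is compound 4 `N#Cc1ccc(Cn2cc(/C=C/C(=O)CC(=O)C(=O)O)c3ccccc32)cc1`, which differs from compound 3 in one place: 4-cyanophenyl in place of 1-methylethenyl on a saturated chain carbon bound to an aromatic nitrogen. Put simply, 4-cyanophenyl stands in place of 1-methylethenyl on a saturated chain carbon bound to an aromatic nitrogen, which turns 2-methylprop-2-en-1-yl into 4-cyanobenzyl.

For the measured compounds named here, no two measured compounds differ in a single place, so no earlier step can serve as a guide. Going by the values given here, the only anchor is compound 3 at 40000 nM in this assay, and any forecast from a single point stays loose. The expected 1.3-fold lower number from compound 3 to compound 4 (0.12 log units; within the scatter) is small, leaning slightly toward stronger inhibition and not clearly beyond the scatter of repeated measurements. For compound 4 the estimated value is 30000 nM, with an expected range from 8000 nM to 100000 nM.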

Compound 4, half-maximal inhibitory concentration: > 40000 nM
Compound 4 gave a limit, no number (the forecaster's own chance of this, stated with the estimate: 30%); middle value at least 1.3-fold (0.12 log units) away from the limit.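

Among these compounds, this is the first step at this position, on a saturated chain carbon bound to an aromatic nitrogen. Replacing 2-methylprop-2-en-1-yl with 4-cyanobenzyl gives a number no lower from compound 3 to compound 4 (the limit leaves the size open) in this assay. Bringing in a six-membered aromatic ring and a nitrile at this place therefore does not yield the stronger inhibitor that a lower number would mark. Compound 4 gives a limit and not a number, so the size of the step cannot be read: the limit of > 40000 nM in this assay, at which 1 of the 4 values shown sits.

The compounds shown leave open whether a plain benzyl without the nitrile, or a longer chain ending in an amine, would bring the number down at this position. Any such change would be judged against compound 3 at 40000 nM, which remains the only firm number in this small family.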